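From naphthalen-2-yl to 4-methoxyphenyl on the amide carbonyl

A few compounds are considered here, and "the series" means these few. Any claim that something is new, unique, unknown or untested is made for them only; others in the source may bear on it.

Compound 1 `O=C(/C=C/c1ccc([N+](=O)[O-])cc1)Nc1cc(Sc2ncn[nH]2)c(O)c2ccccc12` in a functional assay on MDA-MB-231 cells (Homo sapiens) for antiproliferative activity, read by MTT assay, with a stated time of 48 h (a lower number here means a stronger inhibitor, a higher number a weaker inhibitor), gives only a limit of the assay, > 100000 nM.
Compound 2 `O=C(Nc1cc(Sc2ncn[nH]2)c(O)c2ccccc12)c1ccc2ccccc2c1` in this assay gives 45100 nM.
Compound 3 `O=C(Nc1cc(Sc2ncnc3nc[nH]c23)c(O)c2ccccc12)c1ccc(Cl)cc1` in this assay gives 23000 nM.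

Of the two numbers shown, compound 2 lies within the usual scatter of compound 3, so the two cannot be told apart. Compound 1 sits at the limit of > 100000 nM in this assay, at which 1 of the 3 values shown sits. Compound 4 `COc1ccc(C(=O)Nc2cc(Sc3ncn[nH]3)c(O)c3ccccc23)cc1` shares the core of compound 2 and differs in one place: 4-methoxyphenyl in place of naphthalen-2-yl on a carbonyl carbon. For the measured compounds named here, no measured pair shows this change, so the data give no guide to its size. In this assay the step is expected to be small, either none beyond the scatter or a modest move toward a higher number, a 1.1-fold higher number from compound 2 to compound 4 (0.04 log units; within the scatter). Compound 4 is estimated at 50000 nM, with a range from 15000 nM to 150000 nM.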

Compound 4, half-maximal inhibitory concentration: > 100000 nM
Compound 4: no number, only a limit (the forecaster's own chance of this, stated with the estimate: 25%); middle value at least 2.0-fold (0.30 log units) away from the limit.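

In this assay compound 4 gives only a limit of the assay, > 100000 nM. Putting 4-methoxyphenyl in place of naphthalen-2-yl on this carbonyl carbon gives an at least 2.2-fold higher number from compound 2 to compound 4 (0.34 log units; beyond the scatter), so activity at this position does respond to the group placed there. The step ends at a limit, which leaves its full size unknown, and such limits now make up a large share of the values: the limit of > 100000 nM in this assay, at which 2 of the 4 values shown sit.

The compounds shown leave open how a plain phenyl or a 4-aminophenyl group would behave at this position on the same core. Whether the second aromatic ring or the methoxy group matters more therefore remains unsettled.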